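Replacing (pyridin-2-yl)methyl with pyrimidin-2-yl in compound 2

The compounds below may be only part of what the source reports. "The series", "measured", "known", "first", "only" and "open" are said of these compounds alone.

Compound 1 `CC(C)N1CCN(c2cccc3c2C[C@H](CN(C)[C@H]2CCCc4cccnc42)NC3)CC1` gives 15.1%
Compound 2 `CN(C[C@H]1Cc2c(cccc2N2CCN(Cc3ccccn3)CC2)CN1)[C@H]1CCCc2cccnc21` gives 40.4%

In an ADME assay on microsomes from liver (Mus musculus) for metabolic stability, read by LC-MS, with a stated time of 10 min (a lower number here means that less of the compound is left, a higher number that more of the compound is left), compound 2 stands highest of the two measured compounds with 40.4% as its value. Compound 3 `CN(C[C@H]1Cc2c(cccc2N2CCN(c3ncccn3)CC2)CN1)[C@H]1CCCc2cccnc21` is still unmeasured. It carries pyrimidin-2-yl in place of (pyridin-2-yl)methyl on an amine nitrogen in a ring and is otherwise the same as compound 2. Going by the values given here, only one measured step bears on this change, at the same place: (pyridin-2-yl)methyl in place of isopropyl gave a number 25.3 percentage points higher from compound 1 to compound 2 (beyond the scatter) as a modest difference. That single step had another group leaving, so it offers a scale but no firm direction. A small downward step, not clearly beyond the scatter, is therefore expected. In this assay an estimated a number 7.4 percentage points lower from compound 2 to compound 3 (within the scatter) is the expectation. Compound 3 is estimated at 33% with an expected range of 14% to 55% for repeated measurements.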

Compound 3, percent of the compound remaining: 35.1%
Beside the measured number, compound 3's estimate is 2.1 percentage points below it, and the stated range covers the measured number.
By their numbers in this assay, from the lowest: compound 1; then compounds 3 and 2 (each within the scatter of the next).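

In this assay, the step of a number 5.3 percentage points lower from compound 2 to compound 3 (within the scatter) shows that at this ring nitrogen, pyrimidin-2-yl and (pyridin-2-yl)methyl cannot be told apart, even though they differ in ring hetero atoms and heavy atoms. The step of a number 20 percentage points higher from compound 1 to compound 3 (beyond the scatter) shows that (pyridin-2-yl)methyl is no longer the only group to stand clear of isopropyl here, so among these three compounds, both groups bearing a six-membered aromatic ring give higher numbers than isopropyl, and no compound goes against this. No supporting evidence is available on what lies behind these numbers.

The compounds shown leave open whether a phenyl or benzyl group at this nitrogen would group with compound 2 and compound 3 or with compound 1. They also leave open whether the ring nitrogen atoms of the aromatic groups matter at all.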